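Replacing 3-hydroxyazetidin-1-yl in compound 3

The compounds below may be only part of what the source reports. "The series", "measured", "known", "first", "only" and "open" are said of these compounds alone.

In a physicochemical assay for lipophilicity, at pH 7.4 (on this read-out lower numbers stand for lower lipophilicity and higher numbers for higher lipophilicity), compound 1 (`COc1ccc(OCc2cc(C)nc(-c3ccccn3)n2)cc1`) reads 2.8 and compound 2 (`Cc1cc(COc2ccc(F)c(F)c2)nc(-c2ccccn2)n1`) reads 3.2 on the same scale. Compound 3 (`OC1CN(c2cc(COc3ccc(F)c(F)c3F)nc(-c3ccccn3)n2)C1`) reads 2.8 and stands level with compound 1, the two together lowest of the three, while compound 2 lies higher by more than the usual scatter.

Compound 4 (`COC1(COc2cc(COc3ccc(F)c(F)c3F)nc(-c3ccccn3)n2)COC1`) has not yet been measured. Its difference from compound 3 is (3-methoxyoxetan-3-yl)methoxy in place of 3-hydroxyazetidin-1-yl on an aromatic carbon and amounts to (3-methoxyoxetan-3-yl)methoxy in place of 3-hydroxyazetidin-1-yl on an aromatic carbon of the shared core. For the measured compounds named here, no two measured compounds differ in one place only, so the series offers no direct guide to the size of this change. A small upward move in this assay is expected, estimated as a number 0.30 log units higher from compound 3 to compound 4 (within the scatter) and lying near the edge of the scatter. For compound 4 the estimated value is 3.1 with an expected range from 2.7 to 3.5 on this scale.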

Compound 4, distribution coefficient: 3.5
Compound 4: the middle estimate sits 0.40 log units below what was measured, and the stated range covers the measured number.
By their numbers in this assay, from the lowest: compounds 1 and 3 (each within the scatter of the next); then compounds 2 and 4 (each within the scatter of the next).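

For the compounds shown here, at this position, on an aromatic carbon of the shared core next to the ring nitrogen, (3-methoxyoxetan-3-yl)methoxy in place of 3-hydroxyazetidin-1-yl gives the series its only one-place comparison: in this assay, the step is a number 0.70 log units higher from compound 3 to compound 4 (beyond the scatter). The read-out at this position therefore responds to this exchange, in which a four-membered ring is kept on both sides while the hydrogen-bond donor is lost and the group grows. No supporting measurement bears on the step, which alters the atom attached to the core, the group size and the donor count at once, and it is not assigned to any one of these.

Which of these changes carries the step remains open, and a 3-methoxyazetidin-1-yl group at the same place would help separate them. From the compounds shown here alone, how a dimethylamino group or a carboxylic acid at this position reads in this assay also stays open.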